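Swapping a Dichlorophenoxy Arm for a Fluorophenylthio Arm

This account rests on a few compounds, and the source may have more. Where it says the series, first, only, none or still open, it means among the compounds named here.

Measured so far:
Compound 1, `Nc1cc(N)c2nc(-c3ccccc3)c(Oc3ccc(Cl)c(Cl)c3)nc2c1`, in a functional assay on A549 cells (Homo sapiens) for inhibition, read by sulforhodamine B assay, with a stated time of 48 h (on this read-out lower numbers stand for higher toxicity in this test and higher numbers for lower toxicity in this test), gives < 100000 nM.
Compound 2, `CCOC(=O)[C@H](CCC(=O)O)NC(=O)c1ccc(Sc2nc3cc(N)cc(N)c3nc2-c2ccccc2)cc1`, in this assay gives < 100000 nM.

Both values are limits of the test rather than numbers. For compound 1 the result is a limit, so its place on the scale is known only as a boundary: the measurement sits at the limit of < 100000 nM in this assay, at which 2 of the 2 values shown sit, where every value seen so far sits. The same holds for compound 2, whose value is likewise a limit.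

The compound to be measured is compound 3, `Nc1cc(N)c2nc(-c3ccccc3)c(Sc3ccc(F)cc3)nc2c1`. It keeps the core of compound 1 and changes one group: (4-fluorophenyl)sulfanyl in place of 3,4-dichlorophenoxy on an aromatic carbon. Both the leaving and the entering group are single six-membered carbon rings hung on the same aromatic carbon of the shared core, one through oxygen, the other through sulfur.

Going by the values given here, with no measured step on hand, no direction can be read from the data. Compound 3 is expected to land near the same boundary, with a step that the limit leaves unreadable from compound 1 to compound 3 in this assay, that is, none beyond the scatter. The estimate for compound 3 is 30000 nM, within 5000 nM to 100000 nM.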

Compound 3, concentration lethal to 50% of the cells: 70800 nM
Compound 3: the middle estimate sits 2.4-fold (0.37 log units) below what was measured; measured number inside the range.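

In this assay, going by these compounds alone, no step from compound 1 to compound 3 can be read. Compound 1 gives < 100000 nM, which is a limit of the test and not a number. The compounds shown leave open whether (4-fluorophenyl)sulfanyl in place of 3,4-dichlorophenoxy on the shared core changes the value at all, and in which direction.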